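The compounds below may be only part of what the source reports. "The series", "measured", "known", "first", "only" and "open" are said of these compounds alone.

Among the compounds with values here, compound 1 `CN(c1cccc(NC(=O)CN2N=C(C3CCCCC3)c3ccccc3N(CC(=O)C(C)(C)C)C2=O)c1)c1nn[nH]n1` is the only member of the series with a numerical result: in an in vitro assay on PC-3 cells for displacement of a labelled ligand from Cholecystokinin receptor type A (Homo sapiens) (a lower number here means a stronger inhibitor, a higher number a weaker inhibitor), compound 1 gives 6460 nM. Compound 2 `CC(C)(C)C(=O)CN1C(=O)N(CC(=O)Nc2cccc(C(=O)O)c2)N=C(C2CCCC2)c2ccccc21` is reported in this assay only as a limit, < 10000 nM; that entry is the limit of < 10000 nM in this assay, at which 1 of the 2 values shown sits. Compound 3 `CC(C)(C)C(=O)CN1C(=O)N(CC(=O)Nc2cccc(S(=O)(=O)CC(=O)O)c2)N=C(C2CCCCC2)c2ccccc21` differs from compound 1 by (carboxymethyl)sulfonyl in place of (2H-tetrazol-5-yl)(methyl)amino on an aromatic carbon. Within the data shown here, no measured pair differs in one place, so no step size is known from the series. The change is expected to shift this assay only modestly, the step from compound 1 to compound 3 a 1.3-fold lower number from compound 1 to compound 3 (0.11 log units; within the scatter) being estimated as lying within the scatter. Compound 3 is therefore expected at 5000 nM, within a range of 1500 nM to 15000 nM.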

Compound 3, inhibition constant: < 10000 nM
Compound 3: no number, only a limit; the forecaster's own chance of this, stated with the estimate: 25%; the middle value does not contradict the limit.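

Compound 3 carries only a limit, so no step from compound 1 to compound 3 can be read in this assay: the limit of < 10000 nM in this assay, at which 2 of the 3 values shown sit.

The compounds shown leave open whether (carboxymethyl)sulfonyl or (2H-tetrazol-5-yl)(methyl)amino gives the lower number in this assay.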